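The compounds below may be only part of what the source reports. "The series", "measured", "known", "first", "only" and "open" are said of these compounds alone.

In a functional assay on B16 cells (Mus musculus) for cytotoxicity, read by CCK-8 assay, with a stated time of 24 h (on this read-out higher numbers stand for weaker inhibition and lower numbers for stronger inhibition), compound 1 `COc1ccccc1Oc1c(N)nc(-c2ccccc2F)nc1Cl` gives 13800 nM and compound 2 `COc1ccc(-c2nc(N)c(Oc3ccccc3OC)c(OCCO)n2)cc1` gives 18100 nM, so compound 2 stands level with compound 1 within the scatter. Compound 3 `COc1ccccc1Oc1c(N)nc(-c2ccccc2F)nc1OCCO` differs from compound 2 by having 2-fluorophenyl in place of 4-methoxyphenyl on an aromatic carbon. Compound 1 already carries 2-fluorophenyl and gives 13800 nM, so no change beyond the scatter is expected in this assay. The estimated move is a 1.2-fold lower number from compound 2 to compound 3 (0.08 log units; within the scatter). For compound 3, the expected value is 15000 nM, within an estimated range of 7000 nM to 32000 nM.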

Compound 3, half-maximal inhibitory concentration: 11800 nM
For compound 3 the middle estimate is 1.3-fold (0.10 log units) above the measured one; measured number inside the range.
By their numbers in this assay, from the lowest: compounds 3, 1 and 2 (each within the scatter of the next).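

In this assay, 2-fluorophenyl in place of 4-methoxyphenyl on the aromatic carbon between two ring nitrogen atoms gives a 1.5-fold lower number from compound 2 to compound 3 (0.19 log units; within the scatter) and so leaves the read-out within the scatter while the 2-hydroxyethoxy group stays in place. On the other side of the same comparison, 2-hydroxyethoxy in place of chloro gives a 1.2-fold lower number from compound 1 to compound 3 (0.07 log units; within the scatter) and is also within the scatter with 2-fluorophenyl held fixed. No measured evidence here accounts for either step.

Still open, from the compounds shown here alone, is whether a longer chain ending in an amine or a carboxylic acid, in place of 2-hydroxyethoxy, would move the number beyond the scatter.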